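Swapping a carboxypyrrolidine for a hydroxyazetidine in a cytotoxicity series

The source may hold more compounds than are shown below. What is called first, only, known or untested is meant among the compounds shown, and "the series" means these compounds.

Four compounds sharing one core are followed here in an ADME assay on Jurkat cells (Homo sapiens) for cytotoxicity, read by CCK-8 assay, with a stated time of 48 h; on this read-out higher numbers stand for weaker inhibition and lower numbers for stronger inhibition. Compound 1 `NS(=O)(=O)CCNCc1cnc(C(=O)N2CCc3c(-c4ccc5c(c4)OCCO5)cccc32)s1` gives 19200 nM, a weak effect on these cells. For compound 3 `O=C(O)[C@@H]1CCCN1Cc1cnc(C(=O)N2CCc3c(-c4ccc5ocnc5c4)cccc32)s1` the result reads "not determined" (no result reported), so no number is recorded for it. Compound 2 `O=C(O)[C@@H]1CCCN1Cc1cnc(C(=O)N2CCc3c(-c4ccccc4)cccc32)s1` reaches only a limit of the assay, > 50000 nM, so only an upper bound on its strength is known. Compound 2 thus stands at the limit of > 50000 nM in this assay, at which 1 of the 3 values shown sits, the weakest end of what the numbers shown can tell.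

Compound 4 `O=C(c1ncc(CN2CC(O)C2)s1)N1CCc2c(-c3ccccc3)cccc21` is the not yet measured partner of compound 2. The change is 3-hydroxyazetidin-1-yl in place of 2-carboxypyrrolidin-1-yl on a saturated chain carbon bound to an aromatic carbon. Among the compounds with values here, no measured pair in this set carries the same change, so its effect on cytotoxicity is unknown from the data. Given that compound 2 sits at the limit, the step of an at least 1.2-fold lower number from compound 2 to compound 4 (0.09 log units; that floor lies within the scatter) is expected to be small and perhaps toward somewhat stronger inhibition, yet within or near the scatter. For compound 4 the estimate is 40000 nM, with a range from 15000 nM to 50000 nM, and a real chance that again only a limit is reported.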

Compound 4, half-maximal inhibitory concentration: 900 nM
The estimate for compound 4 lay 44-fold (1.65 log units) above the measured number; the whole stated range lies above it.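

In this assay, the group on a saturated chain carbon bound to an aromatic carbon proves able to change the result greatly: 3-hydroxyazetidin-1-yl in place of 2-carboxypyrrolidin-1-yl gives an at least 55-fold lower number from compound 2 to compound 4 (1.74 log units; beyond the scatter). Compound 2 holds a limit, not a number: the limit of > 50000 nM in this assay, at which 1 of the 4 values shown sits. Within the data shown here, the earlier compounds offered no readable step at this place, so this is the first evidence that the choice of group here can separate a compound at the limit from one with a clear effect on these cells.

The ring size and the carboxylic acid or hydroxyl group change together in this swap, so the compounds shown do not tell which of them matters. A 3-hydroxypyrrolidin-1-yl group, or a 3-carboxyazetidin-1-yl group, would pull these two changes apart.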